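The compounds below may be only part of what the source reports. "The series", "measured", "known", "first", "only" and "open" are said of these compounds alone.

The three measured compounds, with their results in a functional assay on CHO cells for agonist activity at hydroxycarboxylic acid receptor 1 (Homo sapiens), read by cAMP accumulation; on this read-out higher numbers stand for an effect only at larger amounts of compound and lower numbers for an effect already at smaller amounts:

Compound 1 `Cc1cc(Cl)c(C(=O)NC(=O)Nc2nc3ccc(S(=O)(=O)C4CCN(C)CC4)cc3s2)cc1-n1cccn1` gives 6100 nM in this assay.
Compound 2 `CCOc1cc(Cl)c(C(=O)NC(=O)Nc2nc3ccc(CN4CCN(C)CC4)cc3s2)cc1N1CCCC1` gives 13 nM in this assay.
Compound 3 `CCOc1cc(Cl)c(C(=O)NC(=O)Nc2nc3ccc(CN4CCN(C)CC4)cc3s2)cc1-n1cccc1` gives 22 nM in this assay.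

Compound 3 stands second highest of the three numbers; compound 2 sits closest to it, and the step of a 1.7-fold higher number from compound 2 to compound 3 (0.23 log units; within the scatter) lies within the scatter. Compound 1 is far away, but it differs from compound 3 in several places at once, so its values show only that a very different set of groups gives a much weaker effect.

Compound 4 `CCOc1ccc(C(=O)NC(=O)Nc2nc3ccc(CN4CCN(C)CC4)cc3s2)c(Cl)c1` differs from compound 3 by hydrogen in place of 1H-pyrrol-1-yl on an aromatic carbon. For the measured compounds named here, the only measured step at that position swaps one five-membered ring for another and changes little; no measured pair removes the group entirely, so the expectation rests on that one step alone. The estimated step of a 2.7-fold higher number from compound 3 to compound 4 (0.44 log units; beyond the scatter) is therefore modest, pointing toward a somewhat higher number. Compound 4 is expected to give about 60 nM in this assay, within a range of 15 nM to 250 nM.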

Compound 4, half-maximal effective concentration: 560 nM
The estimate for compound 4 lay 9.3-fold (0.97 log units) below the measured number; measured number outside the range, above it.
By their numbers in this assay, from the lowest: compounds 2 and 3 (each within the scatter of the next); then compound 4; then compound 1.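

For the compounds shown here, compounds 2 and 3 showed only that one five-membered ring can replace another on this aromatic carbon, ortho to an ethoxy group. With hydrogen there, this assay shows the cost of having no such ring at all: a 25-fold higher number from compound 3 to compound 4 (1.41 log units; beyond the scatter) and a 43-fold higher number from compound 2 to compound 4 (1.63 log units; beyond the scatter). Some group at this position therefore counts for a great deal, and among the two rings shown, the aromatic 1H-pyrrol-1-yl and the saturated pyrrolidin-1-yl serve about equally well, but nothing available explains why hydrogen does so much worse.

Still open, on these data alone, is how much of the ring is needed: an open-chain dimethylamino group might do as well as a ring, or a six-membered piperidin-1-yl ring might do better. It is also unclear whether the effect of removing the ring would be the same size with other groups elsewhere on the shared core.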